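The source may report more compounds than this note shows. Statements on the series, on what has been measured and on what is new or still open speak of the compounds shown alone.

Measured in a functional assay on U2OS cells (Homo sapiens) for antiproliferative activity, read by MTT assay, with a stated time of 72 h; a higher number here means a weaker inhibitor, a lower number a stronger inhibitor:

- compound 1 `O=C(CSc1ncccn1)Nc1ccc2nc(NC(=O)c3ccc(C(F)(F)F)cc3)sc2c1`: 28100 nM
- compound 2 `Cn1c(CNC(=O)c2cccs2)nnc1SCC(=O)Nc1cccc(Cl)c1`: > 100000 nM
- compound 3 `O=C(CSc1ccc(Cl)cc1)Nc1ccc2nc(NC(=O)c3ccc4ccccc4c3)sc2c1`: 14500 nM

Only two of these results are actual numbers. For compound 2, the entry > 100000 nM is a limit of the assay and not a number. In this assay compound 1 gives 28100 nM and compound 3 gives 14500 nM, and these two values lie within the usual scatter of each other. Compound 1 therefore cannot be separated from compound 3 on these results.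

The next compound to be tested is compound 4 `O=C(CSc1ncccc1C(=O)O)Nc1ccc2nc(NC(=O)c3ccc(C(F)(F)F)cc3)sc2c1`. It has 3-carboxypyridin-2-yl in place of the pyrimidin-2-yl of compound 1, on a sulfur, and the rest of the structure stays the same. The counted difference is 3-carboxypyridin-2-yl in place of pyrimidin-2-yl on a sulfur.

Among the compounds with values here, no measured pair of compounds differs in one place only, so there is no direct precedent for this change and any forecast is loose. The expectation here is a modest step to a higher number, meaning a weaker inhibitor. In size, the expected change is a 2.1-fold higher number from compound 1 to compound 4 (0.33 log units; beyond the scatter). For compound 4 the estimated value is 60000 nM, with an expected range from 20000 nM to 100000 nM.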

Compound 4, half-maximal inhibitory concentration: 13600 nM
The estimate for compound 4 lay 4.4-fold (0.64 log units) above the measured number; the whole stated range lies above it.
By their numbers in this assay, from the lowest: compounds 4, 3 and 1 (each within the scatter of the next, the first and the last beyond it). At a limit, above all of these: compound 2.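

Within the data shown here, this is the first pair here that differs in one place only, and it gives a direct reading for the group on the sulfur. In this assay, putting 3-carboxypyridin-2-yl in place of pyrimidin-2-yl gives a 2.1-fold lower number from compound 1 to compound 4 (0.32 log units; beyond the scatter), so a group with more heavy atoms and a hydrogen-bond donor, which pyrimidin-2-yl lacks, is accepted on this sulfur with no loss of antiproliferative activity, and the number even moves modestly lower. Nothing measured in these compounds accounts for the step, so it stands as an observation without an explanation.

As far as these compounds go, the change alters two things at once, the ring and the added carboxylic acid, so the effect of each stays open: pyridin-2-yl without the carboxy group would separate them, and a methyl ester or a primary amide in place of the acid would show whether the acid itself is needed. Among these compounds, whether the same change holds with a different amide at the far end of the shared core, such as the one in compound 3, also remains open.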